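The source may report more compounds than this note shows. Statements on the series, on what has been measured and on what is new or still open speak of the compounds shown alone.

Working notes on the series. Among the compounds with values here, in a functional assay on HL-60 cells (Homo sapiens) for inhibition, read by resazurin assay, with a stated time of 72 h (a higher number here means a weaker inhibitor, a lower number a stronger inhibitor), compound 1 (`CCSc1ccc(C2C(Oc3ccccc3)C(=O)N2c2cc(OC)c(OC)c(OC)c2)cc1`) gives 508 nM, the higher of the two numbers so far, while compound 2 (`CCSc1ccc(C2C(O)C(=O)N2c2cc(OC)c(OC)c(OC)c2)cc1`) gives 16 nM. Within the data shown here, the one measured step, a 32-fold lower number from compound 1 to compound 2 (1.50 log units; beyond the scatter), is beyond the scatter and replaces phenyl with hydrogen on an oxygen on a saturated carbon. Compound 3 (`COc1cc(N2C(=O)C(Oc3ccccc3)C2c2ccc(SC)cc2)cc(OC)c1OC`) keeps that phenyl and differs from compound 1 elsewhere: hydrogen in place of methyl on a saturated chain carbon bound to a sulfur. This is hydrogen in place of methyl on a saturated chain carbon bound to a sulfur, turning ethylsulfanyl into methylsulfanyl. Among the measured compounds shown here, the measured step lies at another place, so it gives no direct size for this change, and no measured pair tests the sulfur chain. No step beyond the scatter is therefore expected in this assay. The expected value for compound 3 is 420 nM, within an estimated range of 170 nM to 1000 nM. The estimate amounts to an expected 1.2-fold lower number from compound 1 to compound 3 (0.08 log units; within the scatter).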

Compound 3, half-maximal inhibitory concentration: 388 nM
Estimate against measurement, compound 3: 1.1-fold (0.03 log units) above; measured number inside the range.
By their numbers in this assay, from the lowest: compound 2; then compounds 3 and 1 (each within the scatter of the next).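

In this assay, the change from ethylsulfanyl to methylsulfanyl now has a measured size: a 1.3-fold lower number from compound 1 to compound 3 (0.12 log units; within the scatter) stays within the scatter. Within the data shown here, with the phenyl kept on the oxygen, then, removing this methyl from the saturated chain carbon bound to a sulfur gives no step that can be told apart from repeat measurement, and the change on the oxygen (a 32-fold lower number from compound 1 to compound 2 (1.50 log units; beyond the scatter)) remains the only step beyond the scatter. No measurement of any other property accompanies this result.

From the compounds shown here alone, it remains open whether the same change would also stay within the scatter with hydrogen on the oxygen, as in compound 2. Also open, going by these compounds, is how a longer chain such as propyl, or an amine on the same ring position as the sulfur chain, would read.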